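Ketone to Primary Amide on the Chain of Compound 2

The source may report more compounds than this note shows. Statements on the series, on what has been measured and on what is new or still open speak of the compounds shown alone.

Measured so far in an assay on A7R5 cells for displacement of a labelled ligand from Endothelin-1 receptor (Rattus norvegicus); on this read-out lower numbers stand for stronger inhibition and higher numbers for weaker inhibition:
compound 1 `COc1cccc(Sc2c(NS(=O)(=O)c3ccc(C(C)(C)C)cc3)noc2CCO)c1`, 770 nM;
compound 2 `COc1cccc(Sc2c(NS(=O)(=O)c3ccc(C(C)(C)C)cc3)noc2CCCC(C)=O)c1`, 1300 nM.

Compound 2 gives the higher of the two numbers, but the step of a 1.7-fold higher number from compound 1 to compound 2 (0.23 log units; within the scatter) places it within the scatter of compound 1, so the two cannot be told apart on this read-out. Compound 3 `COc1cccc(Sc2c(NS(=O)(=O)c3ccc(C(C)(C)C)cc3)noc2CCCC(N)=O)c1` differs from compound 2 by amino in place of methyl on a carbonyl carbon. Going by the values given here, no measured pair shows this ketone-to-amide exchange at the end of the chain; the only step on record, a 1.7-fold higher number from compound 1 to compound 2 (0.23 log units; within the scatter), concerns the chain terminus as well and stayed within the scatter. On that basis the step to compound 3 is expected to be small, a 1.2-fold lower number from compound 2 to compound 3 (0.07 log units; within the scatter), with no direction beyond the scatter. Compound 3 is therefore estimated at 1100 nM in this assay, between 400 nM and 3500 nM.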

Compound 3, half-maximal inhibitory concentration: 6300 nM
Compound 3: the middle estimate sits 5.7-fold (0.76 log units) below what was measured, outside the stated range (above it).
By their numbers in this assay, from the lowest: compounds 1 and 2 (each within the scatter of the next); then compound 3.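

In this assay the end of this chain turns out to be sensitive to a small exchange: amino in place of methyl on a carbonyl carbon gives a 4.8-fold higher number from compound 2 to compound 3 (0.69 log units; beyond the scatter) and so moves the number beyond the scatter, which the step between the two earlier compounds did not do. Carbamoylmethyl in place of hydroxy gives an 8.2-fold higher number from compound 1 to compound 3 (0.91 log units; beyond the scatter) and thus sets compound 3 apart from compound 1 as well as from compound 2, while those two remain indistinguishable. The exchange brings in one hydrogen-bond donor, but nothing measured here accounts for the step.

The compounds shown leave open how a carboxylic acid, a methyl ester or a dimethylamide would read at this chain end. They also leave open whether a longer chain ending in the same carbamoyl group would show the same step.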